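The source may report more compounds than this note shows. Statements on the series, on what has been measured and on what is new or still open speak of the compounds shown alone.

Measured in an ADME assay on MDBK cells (Bos taurus) for cytotoxicity, read by MTT assay, with a stated time of 72 h; on this read-out lower numbers stand for higher toxicity in this test and higher numbers for lower toxicity in this test:
- Compound 1 `FC(F)(F)c1ccc(-c2nn(-c3ccccc3)cc2CNc2ccc(Cl)cc2)cc1`: 44000 nM
- Compound 2 `FC(F)(F)c1ccc(NCc2cn(-c3ccccc3)nc2-c2ccc(C(F)(F)F)cc2)cc1`: 26000 nM
- Compound 3 `Clc1ccc(NCc2cn(-c3ccccc3)nc2-c2ccc(Cl)cc2)cc1`: > 100000 nM, which is a limit of the assay and not a number

Going by the values given here, compound 2 stands at 26000 nM, and the only other true number in the set is close to it: a 1.7-fold lower number from compound 1 to compound 2 (0.23 log units; within the scatter). In that step, trifluoromethyl takes the place of chloro on an aromatic carbon, and the two values cannot be told apart.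

The next compound is compound 4 `Cc1ccc(-c2nn(-c3ccccc3)cc2CNc2ccc(C(F)(F)F)cc2)cc1`. Here methyl takes the place of trifluoromethyl on an aromatic carbon, para to a large group: methyl in place of trifluoromethyl on an aromatic carbon.

Among the compounds with values here, no measured step makes this exact swap. The closest guide is an at least 2.2-fold higher number from compound 1 to compound 3 (0.35 log units; beyond the scatter), which removes the 4-(trifluoromethyl)phenyl group's trifluoromethyl and puts chloro in its place. Going by these compounds, the true size of that step is unknown, as compound 3 sits at the limit of > 100000 nM in this assay, at which 1 of the 3 values shown sits. Chloro is also not methyl, so this guide is only a loose one. It still points towards a higher number in this assay, meaning lower toxicity in this test, and a modest rise is the reasonable expectation.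

The expected change is a 1.7-fold higher number from compound 2 to compound 4 (0.24 log units; within the scatter).

The estimated value for compound 4 is 45000 nM, with an expected range of 20000 nM to 100000 nM.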

Compound 4, half-maximal cytotoxic concentration: > 100000 nM
Compound 4 gave a limit, no number; the forecaster's own chance of this, stated with the estimate: 20%; at least 2.2-fold (0.34 log units) between middle value and limit.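

In this assay, methyl in place of trifluoromethyl gives an at least 3.8-fold higher number from compound 2 to compound 4 (0.58 log units; beyond the scatter), so this change on the 4-(trifluoromethyl)phenyl group moves the read-out towards lower toxicity in this test by more than the usual scatter. The earlier step of an at least 2.2-fold higher number from compound 1 to compound 3 (0.35 log units; beyond the scatter) put chloro on this same position, so both replacements of this trifluoromethyl shown here point the same way, even though the two pairs carry different groups elsewhere in the molecule, and neither step goes against this within the four compounds. Compound 4 gives > 100000 nM, which is a limit of the assay and not a number, so the step has a lower bound but no known size: the limit of > 100000 nM in this assay, at which 2 of the 4 values shown sit.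

Compound 3 and compound 4 both end at this limit, which leaves open how chloro and methyl compare with each other at this position. Going by these compounds, it is also open how the read-out would respond to a group of a different kind here, such as an amine or a carboxylic acid, or to plain hydrogen.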